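Notes on compound 3 at the assay limit

The compounds below may be only part of what the source reports. "The series", "measured", "known", "first", "only" and "open" are said of these compounds alone.

Compound 1 (`Cc1ccc(C2=NN(c3ccc(S(C)(=O)=O)cc3)C(=O)CC2)cc1`) gives > 100000 nM in a functional assay on OVCAR-8 cells (Homo sapiens) for inhibition, read by sulforhodamine B assay, with a stated time of 48 h (on this read-out lower numbers stand for higher toxicity in this test and higher numbers for lower toxicity in this test), as a limit and not a number. Compound 2 (`Cc1cc(O)ccc1C1=NN(c2ccc(S(C)(=O)=O)cc2)C(=O)CC1`) gives > 100000 nM in this assay as a limit too, so compound 2 has no number of its own. The measured step that the two limits leave unreadable from compound 1 to compound 2 has no readable size, and the limit of > 100000 nM in this assay, at which 2 of the 2 values shown sit, is all the evidence so far. Compound 3 (`CCc1ccc(C2=NN(c3ccc(S(C)(=O)=O)cc3)C(=O)CC2)cc1`) brings the change 4-ethylphenyl in place of 4-hydroxy-2-methylphenyl on a carbon with a double bond to nitrogen and so carries 4-ethylphenyl in place of 4-hydroxy-2-methylphenyl on a carbon with a double bond to nitrogen. Within the data shown here, only that one unreadable step bears on this change, so no step beyond the scatter is expected in this assay in either direction. The expected step of a number no higher from compound 2 to compound 3 (the limit leaves the size open) may well prove unreadable. For compound 3 the estimate is 100000 nM with an expected range of 40000 nM to 200000 nM and a report as a limit is the likely outcome.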

Compound 3, concentration lethal to 50% of the cells: > 100000 nM
Compound 3 was reported as a limit; the forecaster's own chance of this, stated with the estimate: 85%; the middle value lies on the limit itself.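

Among these compounds, compound 1, compound 2 and compound 3 are all reported only as limits in this assay, so no step among them can be read: the limit of > 100000 nM in this assay, at which 3 of the 3 values shown sit. The compounds shown leave open whether any change on the shared core gives a readable value in this assay.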